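A few compounds are considered here, and "the series" means these few. Any claim that something is new, unique, unknown or untested is made for them only; others in the source may bear on it.

Of the compounds shown here, two have so far been tested for their effect on cells in an ADME assay on MRC5 cells (Homo sapiens), read by MTT assay, with a stated time of 72 h; on this read-out higher numbers stand for weaker inhibition and lower numbers for stronger inhibition. There, compound 1 `Nc1nc(N)c2c(-c3cc4ccccc4o3)cn([C@@H]3O[C@H](CO)[C@@H](O)[C@H]3O)c2n1` gives 78500 nM, a true measured number. Compound 2 `COc1nc(N)nc2c1c(-c1ccccc1)cn2[C@@H]1O[C@H](CO)[C@@H](O)[C@H]1O` gives > 100000 nM, and this is a limit of the assay and not a number.

Compound 3 `COc1nc(N)nc2c1c(-c1cc3ccccc3o1)cn2[C@@H]1O[C@H](CO)[C@@H](O)[C@H]1O` keeps the rest of compound 2 and changes one group: 1-benzofuran-2-yl stands in place of phenyl, on an aromatic carbon of a five-membered aromatic ring with 1 nitrogen (1-benzofuran-2-yl in place of phenyl on an aromatic carbon).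

Among the compounds with values here, no measured pair shows this change on its own, so any forecast rests on thin ground. Within the data shown here, the one guide is compound 1, which also carries 1-benzofuran-2-yl and reaches a measurable 78500 nM. A small move in this assay towards stronger inhibition is therefore expected, although compound 3 may also end up at the limit of the assay. The estimated change is an at least 1.3-fold lower number from compound 2 to compound 3 (0.12 log units; that floor lies within the scatter). For compound 3 the estimated value is 75000 nM. The expected range for compound 3 runs from 25000 nM to 100000 nM.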

Compound 3, half-maximal inhibitory concentration: 22700 nM
Compound 3: middle estimate off by 3.3-fold (0.52 log units), on the high side, and the stated range ends above it.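

In this assay, within the data shown here, the change from phenyl to 1-benzofuran-2-yl on this aromatic carbon gives an at least 4.4-fold lower number from compound 2 to compound 3 (0.64 log units; beyond the scatter), so this place on the shared core can clearly alter the effect on these cells, which the earlier compounds could not show. From the compounds shown here alone, that step is only a floor, and its true size stays unknown because compound 2 stands at a limit of the assay and not at a true number: the limit of > 100000 nM in this assay, at which 1 of the 3 values shown sits. The second step shows that 1-benzofuran-2-yl does not set the value alone: with that group held constant, methoxy in place of amino on an aromatic carbon gives a 3.5-fold lower number from compound 1 to compound 3 (0.54 log units; beyond the scatter), so the group at this other place also matters.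

The compounds shown do not separate the contribution of the added ring from that of the oxygen in 1-benzofuran-2-yl, a question that furan-2-yl or naphthalen-2-yl at the same place could help to answer. Going by these compounds, it also remains open how far the methoxy result extends to other groups at that place, such as ethoxy or dimethylamino, and whether it would hold with phenyl in place of 1-benzofuran-2-yl.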